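The source may report more compounds than this note shows. Statements on the series, on what has been measured and on what is new or still open speak of the compounds shown alone.

Series notes. Compound 1 `CCc1cccc(NC(=O)CSc2nc(Nc3ccccc3)c3ccccc3n2)c1` is the reference point; in a functional assay on MGC-803 cells (Homo sapiens) for inhibition, read by MTT assay, with a stated time of 72 h (on this read-out higher numbers stand for weaker inhibition and lower numbers for stronger inhibition), compound 1 gives 15800 nM. Compound 2 `O=C(CSc1nc(Nc2ccccc2)c2ccccc2n1)Nc1ccc(Cl)cc1Cl` carries 2,4-dichlorophenyl in place of 3-ethylphenyl on an amide-type nitrogen; in this assay compound 2 gives 12300 nM. Within the data shown here, of the two numbers so far, compound 1 gives the highest, and a 1.3-fold lower number from compound 1 to compound 2 (0.11 log units; within the scatter), so the two measured compounds sit together within the scatter.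

Among the measured compounds shown here, compound 3 `O=C(CSc1nc(Nc2ccccc2)c2ccccc2n1)Nc1ccc(Cl)c(Cl)c1` has not yet been measured in this assay. 3,4-dichlorophenyl in place of 3-ethylphenyl on an amide-type nitrogen The entering group is again a dichlorophenyl on the amide-type nitrogen whose other neighbour is the carbonyl carbon, and the only measured step that bears on it is the closely related change to compound 2, which was a 1.3-fold lower number from compound 1 to compound 2 (0.11 log units; within the scatter). That step lay within the scatter, so no movement beyond the scatter is expected here either, at most a slight drift to a lower number in this assay in line with compound 2's 12300 nM. Compound 3 is therefore expected to give about 12000 nM, with a range of 5000 nM to 30000 nM. The expected step is a 1.3-fold lower number from compound 1 to compound 3 (0.12 log units; within the scatter).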

Compound 3, half-maximal inhibitory concentration: 37900 nM
Beside the measured number, compound 3's estimate is 3.2-fold (0.50 log units) below it, outside the stated range (above it).
By their numbers in this assay, from the lowest: compounds 2 and 1 (each within the scatter of the next); then compound 3.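

In this assay, the amide-type nitrogen proves sensitive to the arrangement of the chlorines and not only to their presence: moving from 2,4-dichlorophenyl to 3,4-dichlorophenyl gives a 3.1-fold higher number from compound 2 to compound 3 (0.49 log units; beyond the scatter), a step beyond the scatter between two groups that differ only in that arrangement. The change from 3-ethylphenyl to 3,4-dichlorophenyl likewise gives a 2.4-fold higher number from compound 1 to compound 3 (0.38 log units; beyond the scatter), so this position can register a change in this assay, which the earlier pair within the scatter did not show, and compound 3 is the weakest of the three, with both of its steps modest in size. No measurement here accounts for the difference between the two dichlorophenyl groups.

Going by these compounds, the three compounds cannot separate the contribution of each chlorine, as 3-chlorophenyl and 4-chlorophenyl are not among them, so it remains open whether one chlorine alone would track with compound 2 or with compound 3. Also open, on these data alone, is how this position would respond to a phenyl carrying an amine or a carboxylic acid, or to a longer chain between the amide-type nitrogen and the ring.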